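Replacing the tert-butoxycarbonyl tail with a hydroxy group

A few compounds are considered here, and "the series" means these few. Any claim that something is new, unique, unknown or untested is made for them only; others in the source may bear on it.

Compound 3 `CC(C)(C)OC(=O)NCC1CCCN(C(=O)CN2CN(c3ccccc3)C3(CCN(C(=O)c4ccc(C(C)(C)C)cc4)CC3)C2=O)C1` carries a ((tert-butoxycarbonyl)amino)methyl group on a six-membered non-aromatic ring with one nitrogen; in an assay on HEK293 cells for displacement of a labelled ligand from NPC1-like intracellular cholesterol transporter 1 (Homo sapiens) (on this read-out higher numbers stand for weaker inhibition and lower numbers for stronger inhibition), compound 3 gives 9500 nM. Among the three measured compounds this is the second highest number. Compound 1 `CC(C)(C)OC(=O)NCCNC(=O)CN1CN(c2ccccc2)C2(CCN(C(=O)c3ccc(C(C)(C)C)cc3)CC2)C1=O` gives 10900 nM in this assay, and compound 2 `CC(C)(C)c1ccc(C(=O)N2CCC3(CC2)C(=O)N(CC(=O)NCCO)CN3c2ccccc2)cc1` gives 1000 nM. The gap between compound 3 and compound 1 lies within the scatter, whereas the gap between compound 3 and compound 2 lies well beyond it.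

Compound 4 `CC(C)(C)c1ccc(C(=O)N2CCC3(CC2)C(=O)N(CC(=O)N2CCCC(O)C2)CN3c2ccccc2)cc1` is the next member of the series: hydroxy in place of ((tert-butoxycarbonyl)amino)methyl on a saturated ring carbon. Within the data shown here, one measured step bears on this change, namely an 11-fold lower number from compound 1 to compound 2 (1.04 log units; beyond the scatter), in which the same kind of tail was exchanged for hydroxy on an open chain rather than on a ring carbon. Among the measured compounds shown here, no measured pair shows the exchange on the ring itself, so carrying that step over is an assumption rather than a reading of the data. On that basis a downward step of similar size is expected: an 8.6-fold lower number from compound 3 to compound 4 (0.94 log units; beyond the scatter). Compound 4 is accordingly estimated at 1100 nM, with a range from 350 nM to 3500 nM.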

Compound 4, half-maximal inhibitory concentration: 12200 nM
Beside the measured number, compound 4's estimate is 11-fold (1.04 log units) below it, outside the stated range (above it).
By their numbers in this assay, from the lowest: compound 2; then compounds 3, 1 and 4 (each within the scatter of the next).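

On the saturated ring carbon, two ring bonds from the ring nitrogen, hydroxy in place of ((tert-butoxycarbonyl)amino)methyl leaves the number in this assay essentially unchanged (a 1.3-fold higher number from compound 3 to compound 4 (0.11 log units; within the scatter)), so the drop seen on the open chain (an 11-fold lower number from compound 1 to compound 2 (1.04 log units; beyond the scatter)) does not carry over to this ring position. A hydroxy group alone therefore does not bring the lower number: with hydroxy present in both compounds, 3-hydroxypiperidin-1-yl in place of (2-hydroxyethyl)amino on a carbonyl carbon costs a large step (a 12-fold higher number from compound 2 to compound 4 (1.09 log units; beyond the scatter)). The same 3-hydroxypiperidin-1-yl group cannot be told apart from (2-((tert-butoxycarbonyl)amino)ethyl)amino on that carbonyl carbon (a 1.1-fold higher number from compound 1 to compound 4 (0.05 log units; within the scatter)), which leaves compound 2 as the only one of the four with a low number.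

Still open, from the compounds shown here alone, is whether an amine or a carboxylic acid on the same ring carbon would depart from this level, and whether a longer chain ending in hydroxy, in place of (2-hydroxyethyl)amino, would keep the lower number of compound 2. Nothing available accounts for the difference between the open-chain exchange and the ring exchange.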